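This account rests on a few compounds, and the source may have more. Where it says the series, first, only, none or still open, it means among the compounds named here.

Measured so far in a functional assay on HeLa cells (Homo sapiens) for cytotoxicity, read by MTT assay, with a stated time of 72 h; a lower number here means a stronger inhibitor, a higher number a weaker inhibitor:

- compound 1 `Nn1c(SCc2cccc([N+](=O)[O-])c2)nnc1-c1c[nH]c2ccccc12` gives 400 nM
- compound 2 `Nn1c(SCc2ccc(F)cc2)nnc1-c1c[nH]c2ccccc12` gives 290 nM
- compound 3 `COc1cccc(CSc2nnc(-c3c[nH]c4ccccc34)n2N)c1` gives 1730 nM

Compound 2 sits at the low end of these numbers, within the scatter of compound 1, while compound 3 lies beyond the scatter of both.

The next compound is compound 4 `COc1ccc(CSc2nnc(-c3c[nH]c4ccccc34)n2N)cc1`. Its difference from compound 2 is methoxy in place of fluoro on an aromatic carbon, in words methoxy in place of fluoro on an aromatic carbon, para to a large group.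

For the measured compounds named here, two measured steps bear on this, and both end at the only measured methoxy compound. The first is a 6.0-fold higher number from compound 2 to compound 3 (0.78 log units; beyond the scatter), which replaces 4-fluorophenyl with 3-methoxyphenyl and is the closest parallel, though the methoxy does not stand where it would in compound 4. The second is a 4.3-fold higher number from compound 1 to compound 3 (0.64 log units; beyond the scatter), with methoxy in place of nitro. Both go to a higher number and both are modest. Going by the values given here, no measured compound carries 4-methoxyphenyl, so the size of the step remains uncertain. A modest rise in this assay is expected, somewhat smaller than the steps above. The expected step is a 3.1-fold higher number from compound 2 to compound 4 (0.49 log units; beyond the scatter). For compound 4 the estimated value is 900 nM, with an expected range from 350 nM to 2300 nM.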

Compound 4, half-maximal inhibitory concentration: 750 nM
The estimate for compound 4 lay 1.2-fold (0.08 log units) above the measured number; measured number inside the range.
By their numbers in this assay, from the lowest: compounds 2, 1 and 4 (each within the scatter of the next, the first and the last beyond it); then compound 3.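

Working notes on the series: in this assay the change from 4-fluorophenyl to 4-methoxyphenyl gives a 2.6-fold higher number from compound 2 to compound 4 (0.41 log units; beyond the scatter) as a direct reading of methoxy in place of fluoro on this aromatic carbon, para to a large group, which the earlier compounds could only approach through a change that also moved the substituent. The step is modest and beyond the scatter, so fluoro is the better of the two groups compared at this place. The series now also holds methoxy at two places on the same phenyl ring, and a 2.3-fold lower number from compound 3 to compound 4 (0.36 log units; beyond the scatter) shows that its placement alone shifts the number beyond the scatter, with 4-methoxyphenyl on the lower side; no measurement at hand accounts for either step.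

Only fluoro and methoxy can be compared at this place, so an unsubstituted phenyl, a chloro group, an amine or a carboxylic acid on the same aromatic carbon remains an open question. A 3-fluorophenyl or a 4-nitrophenyl partner would be needed to tell whether the placement seen with methoxy also holds for fluoro and nitro.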